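The compounds below may be only part of what the source reports. "The series", "measured", "known", "first", "only" and "open" are said of these compounds alone.

Compound 1 `CN1C[C@H](C(=O)Nc2ccccc2F)[C@@H](c2ccc(/C=C/C(=O)Nc3ccccc3N)cc2)C1`: 67 mL/min/kg
Compound 2 `CN1C[C@H](C(=O)Nc2ccc(Cl)cc2F)[C@@H](c2ccc(/C=C/C(=O)Nc3ccccc3N)cc2)C1`: 43 mL/min/kg

In an in vitro ADME assay on microsomes from liver (Mus musculus) for pharmacokinetics, read by LC-MS, with a stated time of 10 min, tested at 1 uM (a lower number here means slower removal, a higher number faster removal of the compound), compound 2 gives 43 mL/min/kg, which lies within the scatter of compound 1 at 67 mL/min/kg. Compound 3 `CN1C[C@H](C(=O)NC2CCCC2)[C@@H](c2ccc(/C=C/C(=O)Nc3ccccc3N)cc2)C1` has not yet been measured. Its structure differs from that of compound 2 in one place: cyclopentyl in place of 4-chloro-2-fluorophenyl on an amide-type nitrogen. Cyclopentyl thus stands in place of 4-chloro-2-fluorophenyl on an amide-type nitrogen.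

Among the measured compounds shown here, only one measured step bears on this change, and only loosely. It is a 1.6-fold lower number from compound 1 to compound 2 (0.19 log units; within the scatter), where chloro replaces hydrogen on an aromatic carbon, and it stays within the scatter. For the measured compounds named here, neither measured compound carries a non-aromatic ring on that nitrogen, so the data offer no direct precedent for the exchange of the whole group. On this thin evidence, no step beyond the scatter is expected in this assay, and no firm direction can be assigned. The estimated change is a 1.3-fold higher number from compound 2 to compound 3 (0.11 log units; within the scatter). The expected value for compound 3 is 55 mL/min/kg, with an estimated range from 25 mL/min/kg to 110 mL/min/kg.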

Compound 3, clearance: 61 mL/min/kg
For compound 3 the middle estimate is 1.1-fold (0.04 log units) below the measured one, and the stated range covers the measured number.
By their numbers in this assay, from the lowest: compounds 2, 3 and 1 (each within the scatter of the next).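

In this assay, this amide-type nitrogen now carries a non-aromatic ring, and cyclopentyl in place of 4-chloro-2-fluorophenyl gives a 1.4-fold higher number from compound 2 to compound 3 (0.15 log units; within the scatter), while cyclopentyl in place of 2-fluorophenyl gives a 1.1-fold lower number from compound 1 to compound 3 (0.04 log units; within the scatter). Both steps lie within the scatter, so this read-out does not separate cyclopentyl from either substituted phenyl group at this position, even though the exchange removes the aromatic ring and the halogens together. No measurement at hand explains this outcome or ties it to any property of these groups.

Every group shown on this nitrogen is a ring of carbon only, so it remains open whether a ring holding nitrogen, such as piperidinyl, an open chain such as pentyl, or a cyclopentyl ring bearing a carboxylic acid would give a step beyond the scatter. Going by these compounds, it also remains open whether the same exchange would give a similar step if the rest of the molecule were changed, since all three compounds share the same remaining structure.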